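A few compounds are considered here, and "the series" means these few. Any claim that something is new, unique, unknown or untested is made for them only; others in the source may bear on it.

The shared core of this small set appears in compound 1 `CCc1ccccc1Nc1ncc2cc(Oc3ccnc(C(=O)NC)c3)ccc2n1`, compound 2 `CNC(=O)c1cc(Oc2ccc3nc(Nc4ccccc4Oc4ccccc4)ncc3c2)ccn1` and compound 3 `CNC(=O)c1cc(Oc2ccc3nc(Nc4cccc(Cl)c4)ncc3c2)ccn1`. In an ADME assay on Caco-2 cells (Homo sapiens) for permeability, in the apical to basolateral direction (on this read-out higher numbers stand for higher permeability and lower numbers for lower permeability), compound 1 gives < 1 10^-6 cm/s, which is a limit of the assay and not a number. In this assay compound 2 likewise returns only a limit, < 1 10^-6 cm/s. Compound 3 also stands at a limit in this assay, < 1 10^-6 cm/s, so its position is known only as a boundary and not as a value. The step that the two limits leave unreadable from compound 1 to compound 2 and the step that the two limits leave unreadable from compound 1 to compound 3 cannot be read in size because every value sits at the limit of < 1 10^-6 cm/s in this assay, at which 3 of the 3 values shown sit. Compound 4 `CNC(=O)c1cc(Oc2ccc3nc(Nc4cccc(OC(F)(F)F)c4)ncc3c2)ccn1` differs from compound 3 in one place: trifluoromethoxy in place of chloro on an aromatic carbon. Neither of the two measured steps bears on this change in a readable way, as both run between limits, and the starting point of compound 3 is itself a limit. On this basis compound 4 is expected to show a step that the limit leaves unreadable from compound 3 to compound 4, which is no change beyond the scatter, with a fair chance that only a limit is reported again. Compound 4 is therefore estimated in this assay at 0.8 10^-6 cm/s, within a range from 0.2 10^-6 cm/s to 3 10^-6 cm/s.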

Compound 4, apparent permeability: < 1 10^-6 cm/s
Compound 4: only a limit was reported; the forecaster's own chance of this, stated with the estimate: 65%; the middle value does not contradict the limit.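

No new step can be read from compound 3 to compound 4, or from compound 1 to compound 4, in this assay, because these results are limits of the assay and not numbers: the limit of < 1 10^-6 cm/s in this assay, at which 4 of the 4 values shown sit. The compounds shown leave open whether any change among compound 1, compound 2, compound 3 and compound 4 alters this read-out at all.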